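Fluoro on the shared core: expectation for compound 4

The compounds below may be only part of what the source reports. "The series", "measured", "known", "first", "only" and "open" are said of these compounds alone.

Measured in a functional assay on HT-29 cells (Homo sapiens) for inhibition, read by CCK-8 assay, with a stated time of 24 h; on this read-out higher numbers stand for weaker inhibition and lower numbers for stronger inhibition:
- compound 1 `O=C1Nc2ccccc2/C1=C/c1ccc(-c2cn(-c3ccc(F)cc3)nn2)cc1`: 17700 nM
- compound 2 `O=C1Nc2ccccc2/C1=C/c1ccc(-c2cn(-c3ccc(Cl)cc3)nn2)cc1`: 14000 nM
- compound 3 `O=C1Nc2ccccc2/C1=C/c1ccc(-c2cn(-c3ccc(Cl)c(C(F)(F)F)c3)nn2)cc1`: 9670 nM

Compound 1 lies within the scatter of both compound 2 and compound 3, so these compounds form one group without a meaningful order. Compound 4 `O=C1Nc2ccc(F)cc2/C1=C/c1ccc(-c2cn(-c3ccc(F)cc3)nn2)cc1` differs from compound 1 by fluoro in place of hydrogen on an aromatic carbon, in a six-membered aromatic ring of carbon only that is part of a fused or bridged system of two rings.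

The measured steps are a 1.3-fold lower number from compound 1 to compound 2 (0.10 log units; within the scatter), a 1.4-fold lower number from compound 2 to compound 3 (0.16 log units; within the scatter) and a 1.8-fold lower number from compound 1 to compound 3 (0.26 log units; within the scatter). All three stay within the scatter, but none touches the ring that takes the new fluoro, so the data offer only indirect evidence for this change. No step beyond the scatter is therefore expected in this assay, and no firm direction is expected.

The expected step is a 1.2-fold lower number from compound 1 to compound 4 (0.07 log units; within the scatter). For compound 4 the estimated value is 15000 nM, with an expected range of 8000 nM to 28000 nM.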

Compound 4, half-maximal inhibitory concentration: 20000 nM
For compound 4 the middle estimate is 1.3-fold (0.12 log units) below the measured one, within the range that was stated.
By their numbers in this assay, from the lowest: compounds 3, 2, 1 and 4 (each within the scatter of the next, the first and the last beyond it).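

In this assay, fluoro in place of hydrogen gives a 1.1-fold higher number from compound 1 to compound 4 (0.05 log units; within the scatter) and stays within the scatter. This is the first step shown on the six-membered aromatic ring of carbon only that is part of the fused system of the shared core, whereas the earlier steps all changed the aryl group on the aromatic nitrogen. At this position, a single fluoro therefore brings no readable change in this read-out, and no measurement at hand bears on this result.

The compounds shown leave open whether a larger or differently charged group at this position, such as a methoxy group, an amine or a carboxylic acid, would move the number beyond the scatter. They also leave open whether the same fluoro would give a similar step with the 4-chloro-3-(trifluoromethyl)phenyl group of compound 3 on the aromatic nitrogen.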